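Phenoxymethyl in place of methoxybenzyl on the piperidine arm

The compounds below may be only part of what the source reports. "The series", "measured", "known", "first", "only" and "open" are said of these compounds alone.

Three compounds sharing one carbamoyl-triazole core have been examined in an assay on HEK-293T cells for inhibition of diacylglycerol lipase-alpha (Homo sapiens), read by colorimetric assay; a lower number here means a stronger inhibitor, a higher number a weaker inhibitor. Compound 1 `O=C(N1CCCC[C@@H]1Cc1ccccc1)n1ncc(C(O)(c2ccc(F)cc2)c2ccc(F)cc2)n1` gives 0.794 nM. Compound 2 `CCC1CCCCN1C(=O)n1ncc(-c2ccc(-c3ccccc3)cc2)n1`, which carries a biphenyl group on the triazole instead of the bis(fluorophenyl)carbinol and an ethyl group on the ring, gives 3980 nM. Compound 3 `COc1ccc(CC2CCCCN2C(=O)n2ncc(C(O)(c3ccc(F)cc3)c3ccc(F)cc3)n2)cc1` gives 5.01 nM, a number that lies between the other two but far nearer to compound 1 than to compound 2; its gap to compound 1 and its gap to compound 2 both lie beyond the usual scatter.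

Compound 4 `O=C(N1CCCCC1COc1ccccc1)n1ncc(C(O)(c2ccc(F)cc2)c2ccc(F)cc2)n1` has not yet been measured. It differs from compound 3 in one place: phenoxy in place of 4-methoxyphenyl on a saturated chain carbon bound to a saturated ring carbon. The bis(fluorophenyl)carbinol and the rest of the core are unchanged.

Since compound 1 with a plain benzyl group gives 0.794 nM and compound 3 with a 4-methoxybenzyl group gives 5.01 nM, the phenoxymethyl arm of compound 4 is expected to fall in the same region. The step of a 1.7-fold lower number from compound 3 to compound 4 (0.22 log units; within the scatter) is expected to be small, a slight move toward a lower number that may well stay within the scatter. Compound 4 is therefore estimated at 3 nM, with a range from 0.8 nM to 12 nM.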

Compound 4, half-maximal inhibitory concentration: 5.01 nM
For compound 4 the middle estimate is 1.7-fold (0.22 log units) below the measured one; the measured number falls inside the stated range.
By their numbers in this assay, from the lowest: compound 1; then compounds 3 and 4 (each within the scatter of the next); then compound 2.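

In this assay, replacing the 4-methoxybenzyl arm with phenoxymethyl gives no change at the digits printed from compound 3 to compound 4 (within the scatter), and this is the only single-place comparison among the compounds shown. Within the data shown here, it gives the first direct reading at this position: with the bis(fluorophenyl)carbinol and the rest of the core unchanged, phenoxy in place of 4-methoxyphenyl on a saturated chain carbon bound to a saturated ring carbon leaves the two compounds indistinguishable in this measurement, even though the group that enters has one heavy atom fewer and the aromatic ring and the count of one hydrogen-bond acceptor stay the same. No evidence is available that bears on why the two arms read alike.

The compounds shown leave open whether this equivalence would hold for a different link at the same place, such as an amine in place of the oxygen of the phenoxymethyl arm or a longer chain carrying the phenoxy group. They also leave open how a carboxylic acid or a chlorine atom on the phenoxy ring would read in this assay.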